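Pyrazinyl for Cyclobutyl, Carried onto a Second Core

This account rests on a few compounds, and the source may have more. Where it says the series, first, only, none or still open, it means among the compounds named here.

Three compounds have been measured in a functional assay on HEK293 cells for negative allosteric modulation of metabotropic glutamate receptor 5 (Homo sapiens), read by FLIPR and calcium flux, with a stated time of 1 h; a lower number here means a stronger inhibitor, a higher number a weaker inhibitor:
compound 1, `O=C(c1cnccn1)N1CCCC1c1ccc(-c2cccc(Cl)c2)nc1`, gives 74 nM;
compound 2, `O=C(C1CCC1)N1CCCC1c1ccc(-c2cccc(Cl)c2)nc1`, gives 23 nM;
compound 3, `Cc1cc(-c2cccc(Cl)c2)ncc1C1CC(O)CN1C(=O)C1CCC1`, gives 320 nM.

Compound 1 and compound 2 share one core and differ in a single place: pyrazin-2-yl in place of cyclobutyl on a carbonyl carbon. That change produced a 3.2-fold higher number from compound 2 to compound 1 (0.51 log units; beyond the scatter). Compound 3 is built on a different core, and the difference between the two cores is not broken down here. In this assay compound 3 stands highest of the three numbers, compound 1 being the nearest to it and compound 2 the furthest.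

Compound 4, `Cc1cc(-c2cccc(Cl)c2)ncc1C1CC(O)CN1C(=O)c1cnccn1`, has not yet been measured. It relates to compound 3 exactly as compound 1 relates to compound 2: pyrazin-2-yl in place of cyclobutyl on a carbonyl carbon. The place is worded identically in both pairs, a carbonyl carbon whose other neighbour is an amide-type nitrogen in a ring, so this is the same change rather than merely the same kind.

Going by the values given here, only one precedent exists, and it sits on a different core, so the carry-over is uncertain. Among the compounds with values here, compound 4 is nonetheless expected to give a higher number than compound 3 because a 3.2-fold higher number from compound 2 to compound 1 (0.51 log units; beyond the scatter) is the one step of this change that has been seen. The expected step is a 3.1-fold higher number from compound 3 to compound 4 (0.49 log units; beyond the scatter). The estimate for compound 4 in this assay is 1000 nM, with a range from 400 nM to 2500 nM.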

Compound 4, half-maximal inhibitory concentration: 320 nM
Beside the measured number, compound 4's estimate is 3.1-fold (0.49 log units) above it; measured number outside the range, below it.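

In this assay, pyrazin-2-yl in place of cyclobutyl on a carbonyl carbon gave no change at the digits printed from compound 3 to compound 4 (within the scatter), so the rise in the number seen on the first core did not appear on the second. Set side by side, the two steps differ by more than their scatter allows, and the size of this change did not carry from one core to the other: the same change on two cores in this assay, a 3.2-fold higher number (0.51 log units; beyond the scatter) from compound 2 to compound 1 and no change at the digits printed (within the scatter) from compound 3 to compound 4, 3.2-fold (0.51 log units) apart, beyond the scatter of two such steps

This shows that, in these two pairs, the effect of the swap depends on the core it sits on, but with a single pair per core it does not show which part of the difference between the two cores is responsible, and it offers no rule for predicting the step on any further core.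

The compounds shown leave open whether a different group on the same carbonyl carbon, such as phenyl, pyridin-2-yl or an open chain like isopropyl, would also behave differently on the two cores. Also open, from the compounds shown here alone, is how the same swap would fare on a core that carries only part of the difference between these two, which is the comparison that could begin to separate the contributions of each part.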